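The compounds below may be only part of what the source reports. "The series", "measured", "known", "first", "only" and "open" are said of these compounds alone.

Measured so far in an assay on brain for displacement of a labelled ligand from D(3) dopamine receptor (Rattus norvegicus); on this read-out higher numbers stand for weaker inhibition and lower numbers for stronger inhibition:
compound 1, `CCCN(CC[C@H]1CC[C@H](NC(=O)/C=C/c2ccc(F)cc2)CC1)[C@H]1CCc2nc(N)sc2C1`: 1 nM
compound 2, `CCCN(CC[C@H]1CC[C@H](NC(=O)/C=C/c2ccccc2OC)CC1)[C@H]1CCc2nc(N)sc2C1`: 8.1 nM

Compound 2 stands at the highest of the two numbers; its nearest neighbour is compound 1, and the step of an 8.1-fold higher number from compound 1 to compound 2 (0.91 log units; beyond the scatter) lies beyond the scatter, a modest change brought by a 2-methoxyphenyl in place of a 4-fluorophenyl on the double-bonded chain carbon.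

Compound 3, `CCCN(CC[C@H]1CC[C@H](NC(=O)c2ccc(-c3noc(C)n3)cc2)CC1)[C@H]1CCc2nc(N)sc2C1`, is the next case. It differs from compound 2 in this way: 4-(5-methyl-1,2,4-oxadiazol-3-yl)phenyl in place of 2-(2-methoxyphenyl)ethenyl on a carbonyl carbon

Going by the values given here, the one measured step concerns only the aryl group at the end of the ethenyl chain, whereas here the whole 2-(2-methoxyphenyl)ethenyl is exchanged for an aryl bound directly to the carbonyl carbon. Among the compounds with values here, no measured pair tells how this assay responds to such an exchange, so the direction rests on the sole step available, which was modest in size. Compound 3 is expected to give 4 nM in this assay, within 1 nM to 20 nM, an estimated step of a 2.0-fold lower number from compound 2 to compound 3 (0.31 log units; beyond the scatter).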

Compound 3, inhibition constant: 1.3 nM
Compound 3: middle estimate off by 3.1-fold (0.49 log units), on the high side; the measured number falls inside the stated range.
By their numbers in this assay, from the lowest: compounds 1 and 3 (each within the scatter of the next); then compound 2.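

In this assay, the exchange on the carbonyl carbon gives a 6.2-fold lower number from compound 2 to compound 3 (0.79 log units; beyond the scatter), so an aryl bound directly to that carbon can replace the 2-(2-methoxyphenyl)ethenyl group, and among these compounds the double bond outside aromatic rings is not needed for a low number. Measured against the other ethenyl compound, the same exchange gives a 1.3-fold higher number from compound 1 to compound 3 (0.11 log units; within the scatter), so 4-(5-methyl-1,2,4-oxadiazol-3-yl)phenyl and 2-(4-fluorophenyl)ethenyl cannot be told apart here, although they differ in ring content and in counted hydrogen-bond acceptors. Nothing available accounts for either step.

Still open is how much of the result depends on the 5-methyl-1,2,4-oxadiazol-3-yl group, since a plain phenyl on the carbonyl carbon is not among the compounds shown. Also open, from the compounds shown here alone, is how this assay responds to a carboxylic acid or a primary amine in place of that group.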